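Swapping Hydroxy for Dimethylamino on Compound 1

The source may hold more compounds than are shown below. What is called first, only, known or untested is meant among the compounds shown, and "the series" means these compounds.

Among the measured compounds shown here, in a functional assay on MCF7 cells (Homo sapiens) for antiproliferative activity, read by MTT assay, with a stated time of 48 h (a higher number here means a weaker inhibitor, a lower number a stronger inhibitor), compound 1 (`COc1ccc(C(=O)c2cc(OC)c(OC)c(OC)c2)c(NC(=O)CO)c1`) gives 230 nM, the lower of the two numbers measured so far. Compound 2 (`C=C(c1ccc(OC)cc1NC(=O)CO)c1ccc(OC)c2c1C=CC(C)(C)O2`) gives 590 nM, a gap beyond the usual scatter. Compound 3 (`COc1ccc(C(=O)c2cc(OC)c(OC)c(OC)c2)c(NC(=O)CN(C)C)c1`) keeps the core of compound 1 but has dimethylamino in place of hydroxy on a saturated chain carbon bound to a carbonyl carbon. For the measured compounds named here, no measured pair shows this change, so the expectation is only a small weakening. The expected step is a 2.2-fold higher number from compound 1 to compound 3 (0.34 log units; beyond the scatter). For compound 3 the estimate is 500 nM, with an expected range from 120 nM to 2500 nM.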

Compound 3, half-maximal inhibitory concentration: 790 nM
For compound 3 the middle estimate is 1.6-fold (0.20 log units) below the measured one; measured number inside the range.
By their numbers in this assay, from the lowest: compound 1; then compounds 2 and 3 (each within the scatter of the next).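

In this assay, putting dimethylamino in place of hydroxy on this saturated chain carbon gives a 3.4-fold higher number from compound 1 to compound 3 (0.54 log units; beyond the scatter), so the position responds to the change, though only modestly. Hydroxy has a hydrogen-bond donor and dimethylamino has none, but this single pair cannot show whether that difference or some other one matters. No available evidence explains the step. Open, from the compounds shown here alone, is how an unsubstituted amino group or methoxy at this place would compare with hydroxy, and whether a longer chain would change the number.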